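Replacing the Aryl Group on the Ring Nitrogen: Compound 3

This account rests on a few compounds, and the source may have more. Where it says the series, first, only, none or still open, it means among the compounds named here.

Measured so far:
compound 1, `C#Cc1cccc(Nc2ncnc3cc(OC)c(OCCCCC(=O)Nc4ccc(S(N)(=O)=O)cc4)cc23)c1`, 17700 nM
compound 2, `COc1cc2ncnc(Nc3cc(F)c(F)c(F)c3)c2cc1OCCCCC(=O)Nc1ccc(S(N)(=O)=O)cc1`, 23400 nM

In a functional assay on A-431 cells (Homo sapiens) for antiproliferative activity, read by MTT assay, with a stated time of 72 h (a higher number here means a weaker inhibitor, a lower number a stronger inhibitor), compound 1 gives 17700 nM, and compound 2 gives 23400 nM. Among the measured compounds shown here, the single step joining them, a 1.3-fold higher number from compound 1 to compound 2 (0.12 log units; within the scatter), leaves the two within the scatter of each other, so compound 2 stands beside compound 1 with no separation that the assay can resolve.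

Compound 3 `COc1ccccc1Nc1ncnc2cc(OC)c(OCCCCC(=O)Nc3ccc(S(N)(=O)=O)cc3)cc12` differs from compound 2 in one place: 2-methoxyphenyl in place of 3,4,5-trifluorophenyl on a nitrogen on an aromatic ring. For the measured compounds named here, no measured step covers an exchange into a 2-methoxyphenyl group. Going by the values given here, the only known step at this nitrogen, the one from compound 1 to compound 2, was within the scatter, which gives no ground to expect a change in this assay beyond it. The estimate is therefore a 1.1-fold lower number from compound 2 to compound 3 (0.05 log units; within the scatter), and compound 3 is expected to give about 21000 nM, between 6000 nM and 70000 nM.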

Compound 3, half-maximal inhibitory concentration: 24200 nM
Compound 3: middle estimate off by 1.2-fold (0.06 log units), on the low side, within the range that was stated.
By their numbers in this assay, from the lowest: compounds 1, 2 and 3 (each within the scatter of the next).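

In this assay the exchange of 3,4,5-trifluorophenyl for 2-methoxyphenyl on the nitrogen gives a 1.0-fold higher number from compound 2 to compound 3 (0.01 log units; within the scatter) and the exchange of 3-ethynylphenyl for 2-methoxyphenyl gives a 1.4-fold higher number from compound 1 to compound 3 (0.14 log units; within the scatter). Three different aryl groups on this nitrogen now stand within the scatter of one another, which one step between two compounds could not show. That holds even though the entering group brings an oxygen and one hydrogen-bond acceptor, which 3,4,5-trifluorophenyl lacks.

Still open, on these data alone, is whether an amine or a carboxylic acid on this aryl ring would separate from these three compounds. Also open, as far as these compounds go, is whether a longer chain in the shared remainder of the molecule would do so. No measurement given here accounts for these results.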